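The source may report more compounds than this note shows. Statements on the series, on what has been measured and on what is new or still open speak of the compounds shown alone.

The compounds measured so far:
- compound 1, `COc1ccc(-n2ncnc2-c2cc(OC)c(OC)c(OC)c2)cc1`: 7400 nM
- compound 2, `COc1cc(-n2ncnc2-c2cccc(F)c2)cc(OC)c1OC`: reported only as a limit, > 10000 nM
- compound 3, `COc1ccc(-c2ncnn2-c2cc(OC)c(OC)c(OC)c2)cc1`: 360 nM

In a functional assay on MCF7 cells (Homo sapiens) for antiproliferative activity, read by MTT assay, with a stated time of 72 h (a higher number here means a weaker inhibitor, a lower number a stronger inhibitor), compound 1 stands highest of the two numbers given. Among the measured compounds shown here, compound 3 lies below compound 1, and no single-point step connects the two. Compound 2 sits at the assay limit, (the limit of > 10000 nM in this assay, at which 1 of the 3 values shown sits), so it contributes no number.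

For the measured compounds named here, the only step between two measured compounds runs from compound 2 to compound 3, an at least 27-fold lower number from compound 2 to compound 3 (1.44 log units; beyond the scatter), with 4-methoxyphenyl in place of 3-fluorophenyl on an aromatic carbon. It shows that, on that ring, a methoxyphenyl in place of a halogenated phenyl brought a large drop in the number.

Compound 4, `COc1cc(-c2ncnn2-c2ccc(Cl)cc2)cc(OC)c1OC`, differs from compound 1 by chloro in place of methoxy on an aromatic carbon. This is the reverse kind of exchange, a methoxy giving way to a halogen, though on the other phenyl ring and without a matching measured pair. Taking the measured step as the nearest guide, the number for compound 4 is expected to rise rather than fall, and it may well reach the limit. Compound 4 is therefore estimated at 9000 nM, between 3000 nM and 25000 nM. That estimate means a step of a 1.2-fold higher number from compound 1 to compound 4 (0.09 log units; within the scatter).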

Compound 4, half-maximal inhibitory concentration: > 10000 nM
Compound 4 was reported as a limit; the forecaster's own chance of this, stated with the estimate: 40%; middle value at least 1.1-fold (0.04 log units) away from the limit.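

In this assay, exchanging methoxy for chloro on the aromatic carbon para to a large group gives an at least 1.3-fold higher number from compound 1 to compound 4 (0.13 log units; that floor lies within the scatter). Among the compounds shown here, this is the first direct reading of a change at this position, and it shows that chloro here brings no gain in activity, while the true size of the change stays unknown: the step is only a floor, and that floor does not clear the scatter. The value of compound 4 is a limit and not a number, so this compound joins compound 2 among those that give no measured value: the limit of > 10000 nM in this assay, at which 2 of the 4 values shown sit.

The compounds shown leave open whether the methoxy itself matters at this position or whether another group there, such as an amine, a hydroxyl or an ethoxy, would move the number in either direction. For the compounds shown here, they also leave open how far chloro really stands from methoxy on this ring, since one end of the only comparison at this position is a limit.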